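A methyl added to an already inactive cyclohexyl amide

The source may hold more compounds than are shown below. What is called first, only, known or untested is meant among the compounds shown, and "the series" means these compounds.

Compound 1 `O=C(C1CC1)N1CCc2nc(C#Cc3ccccc3)sc2C1` gives 290 nM in an assay on HEK293 cells for negative allosteric modulation of metabotropic glutamate receptor 5 (Homo sapiens), read by FLIPR, with a stated time of 1 h; on this read-out lower numbers stand for stronger inhibition and higher numbers for weaker inhibition. Compound 2 `O=C(C1CC12CCC2)N1CCc2nc(C#Cc3ccccc3)sc2C1` reaches only the limit > 10000 nM in this assay. Compound 3 `O=C(C1CCCCC1)N1CCc2nc(C#Cc3ccccc3)sc2C1` likewise stops at the limit > 10000 nM in this assay. Two of the three values therefore sit at the limit of > 10000 nM in this assay, at which 2 of the 3 values shown sit. The steps of an at least 34-fold higher number from compound 1 to compound 2 (1.53 log units; beyond the scatter) and an at least 34-fold higher number from compound 1 to compound 3 (1.53 log units; beyond the scatter) show that enlarging the ring on the carbonyl carbon strongly weakens inhibition, whereas a step that the two limits leave unreadable from compound 2 to compound 3 cannot be read. Compound 4 `CC1CCC(C(=O)N2CCc3nc(C#Cc4ccccc4)sc3C2)CC1` differs from compound 3 by methyl in place of hydrogen on a saturated ring carbon, that is, cyclohexyl to 4-methylcyclohexyl. Compound 3 already lies at the limit, and the added methyl is expected to leave it there. The estimated step is a step that the limit leaves unreadable from compound 3 to compound 4, from one limit to another. Compound 4 is expected to give 20000 nM, between 7000 nM and 100000 nM.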

Compound 4, half-maximal inhibitory concentration: > 10000 nM
Compound 4: a limit, no number (the forecaster's own chance of this, stated with the estimate: 85%); the middle value lies beyond the limit too.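

Compound 4, which carries 4-methylcyclohexyl, stops at a limit, > 10000 nM, and so gives no number. Measured against the cyclopropyl amide, the change reads as an at least 34-fold higher number from compound 1 to compound 4 (1.53 log units; beyond the scatter), while the steps among compound 2, compound 3 and compound 4 cannot be read. Adding methyl to the cyclohexyl ring therefore brings no inhibition back into the readable range, and most of the series now sits at one ceiling: the limit of > 10000 nM in this assay, at which 3 of the 4 values shown sit.

From the compounds shown here alone, whether cyclobutyl on the carbonyl carbon keeps any inhibition stays open. So does whether an amine on the cyclohexyl ring would give a readable number.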